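Nitro to dimethylamino on the benzoyl ring of compound 2

This account rests on a few compounds, and the source may have more. Where it says the series, first, only, none or still open, it means among the compounds named here.

Compound 1 `CC(/C=N/Nc1ccc([N+](=O)[O-])cc1)=N\NC(=O)c1ccc(O)cc1` gives 51000 nM in an ADME assay on J774 cells (Mus musculus, strain BALB/c) for cytotoxicity, read by resazurin assay, with a stated time of 72 h; a lower number here means that less compound is tolerated, a higher number that more compound is tolerated.
Compound 2 `CC(/C=N/Nc1ccc([N+](=O)[O-])cc1)=N\NC(=O)c1ccc([N+](=O)[O-])cc1` reaches only a limit of this assay, namely > 100000 nM.

Compound 2 thus stands at the upper boundary, as the limit of > 100000 nM in this assay, at which 1 of the 2 values shown sits, shows. Compound 3 `CC(/C=N/Nc1ccc([N+](=O)[O-])cc1)=N\NC(=O)c1ccc(N(C)C)cc1` differs from compound 2 by dimethylamino in place of nitro on an aromatic carbon. Going by the values given here, only the step of an at least 1.9-fold higher number from compound 1 to compound 2 (0.29 log units; that floor lies within the scatter) bears on this change, and it lies within the scatter, so no direction can be read from it. For compound 3 a step of an at least 1.4-fold lower number from compound 2 to compound 3 (0.15 log units; that floor lies within the scatter) in this assay is therefore expected. Compound 3 is estimated at 70000 nM, with a range from 25000 nM to 200000 nM.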

Compound 3, half-maximal cytotoxic concentration: > 100000 nM
Compound 3 was reported as a limit (the forecaster's own chance of this, stated with the estimate: 35%); middle value at least 1.4-fold (0.15 log units) away from the limit.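

In this assay compound 3 ends at a limit of the assay, as compound 2 does, so the step between them cannot be read: the limit of > 100000 nM in this assay, at which 2 of the 3 values shown sit. What is new is that dimethylamino, like nitro, reaches this limit at this aromatic carbon. Dimethylamino in place of hydroxy gives an at least 1.9-fold higher number from compound 1 to compound 3 (0.29 log units; that floor lies within the scatter), so this step also fixes no direction.

The compounds shown leave open where compound 2 and compound 3 truly lie beyond the limit. They also leave open whether a carboxylic acid or a primary amine at this place would give a readable number.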